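The source may report more compounds than this note shows. Statements on the series, on what has been measured and on what is new or still open speak of the compounds shown alone.

Compound 1 `N#CC1=C(N)Oc2c(N)cc3nc4ccccc4nc3c2C12C(=O)N(Cc1cnnn1-c1ccc(Cl)cc1)c1ccccc12`, compound 2 `N#CC1=C(N)Oc2c(N)cc3nc4ccccc4nc3c2C12C(=O)N(Cc1cnnn1-c1ccccc1Cl)c1ccccc12` and compound 3 `CCOc1ccc(-n2nncc2CN2C(=O)C3(C(C#N)=C(N)Oc4c(N)cc5nc6ccccc6nc5c43)c3ccccc32)cc1` share one core and differ only in the aryl group on an aromatic nitrogen. In a functional assay on HCT-116 cells (Homo sapiens) for antiproliferative activity, read by MTT assay, with a stated time of 48 h (on this read-out lower numbers stand for stronger inhibition and higher numbers for weaker inhibition), compound 1 gives only a limit, > 50000 nM. Compound 2 likewise gives only a limit, > 50000 nM. Compound 3 also returns only a limit, > 50000 nM. Accordingly a step that the two limits leave unreadable from compound 1 to compound 2, a step that the two limits leave unreadable from compound 1 to compound 3 and a step that the two limits leave unreadable from compound 2 to compound 3 cannot be sized, as the limit of > 50000 nM in this assay, at which 3 of the 3 values shown sit, shows. Compound 3 therefore stands at the limit together with both others. Compound 4 `N#CC1=C(N)Oc2c(N)cc3nc4ccccc4nc3c2C12C(=O)N(Cc1cnnn1-c1ccc([N+](=O)[O-])cc1[N+](=O)[O-])c1ccccc12` carries 2,4-dinitrophenyl in place of 4-ethoxyphenyl on an aromatic nitrogen. Among the compounds with values here, none of the measured steps gives a readable size for a change of this kind, so no shift beyond the scatter is expected. Compound 4 is estimated at 50000 nM (range 20000 nM to 100000 nM). The expected step is a number no higher from compound 3 to compound 4 (the limit leaves the size open).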

Compound 4, half-maximal inhibitory concentration: 23900 nM
The estimate for compound 4 lay 2.1-fold (0.32 log units) above the measured number; the measured number falls inside the stated range.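

In this assay, within the data shown here, replacing the aryl group on the aromatic nitrogen with 2,4-dinitrophenyl gives the first readable steps: an at least 2.0-fold lower number from compound 3 to compound 4 (0.32 log units; beyond the scatter), an at least 2.0-fold lower number from compound 2 to compound 4 (0.32 log units; beyond the scatter) and an at least 2.0-fold lower number from compound 1 to compound 4 (0.32 log units; beyond the scatter). This position can therefore shift the number, which compound 1, compound 2 and compound 3 could not show, though each step gives only a minimum size: the limit of > 50000 nM in this assay, at which 3 of the 4 values shown sit.

On these data alone, whether one nitro group would suffice remains open. So does the outcome of placing an amine or a carboxylic acid on this aryl ring.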